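The source may report more compounds than this note shows. Statements on the series, on what has been measured and on what is new or still open speak of the compounds shown alone.

Of the compounds shown here, three on one shared core have been read in an ADME assay on Vero cells (Chlorocebus sabaeus) for antiproliferative activity, read by MTT assay, with a stated time of 72 h (on this read-out higher numbers stand for weaker inhibition and lower numbers for stronger inhibition), and none of them gives a number. Compound 1 `CN(c1ccccc1)S(=O)(=O)C1CC2OC1C(c1ccc(NC(=O)CCCCCCC(=O)O)cc1)=C2c1ccc(O)cc1` gives > 100000 nM as its reading, which is a limit of the assay. Compound 2 `CCN(c1ccccc1)S(=O)(=O)C1CC2OC1C(c1ccc(NC(=O)CCCCCCC(=O)O)cc1)=C2c1ccc(O)cc1` gives > 100000 nM as its reading, again a limit. Compound 3 `CCN(c1ccc(C)cc1)S(=O)(=O)C1CC2OC1C(c1ccc(NC(=O)CCCCCCC(=O)O)cc1)=C2c1ccc(O)cc1` gives > 100000 nM as its reading, also a limit. Where compound 3 stands is therefore told only by the limit of > 100000 nM in this assay, at which 3 of the 3 values shown sit, and not by a measured value.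

Compound 4 `CCN(c1ccc(Cl)cc1)S(=O)(=O)C1CC2OC1C(c1ccc(NC(=O)CCCCCCC(=O)O)cc1)=C2c1ccc(O)cc1` carries chloro in place of methyl on an aromatic carbon, para to a large group, and the change counts as chloro in place of methyl on an aromatic carbon when the two structures are compared. The nearest measured change is a step that the two limits leave unreadable from compound 2 to compound 3 and the others are a step that the two limits leave unreadable from compound 1 to compound 2 and a step that the two limits leave unreadable from compound 1 to compound 3 so none offers a size to carry over. In this assay no step beyond the scatter is expected, and no direction is favoured. The expected outcome is a number no higher from compound 3 to compound 4 (the limit leaves the size open) with a further limit as the likeliest report. Compound 4 is expected near 100000 nM with an estimated range from 40000 nM to 200000 nM as its span.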

Compound 4, half-maximal inhibitory concentration: > 100000 nM
Compound 4 was reported as a limit (the forecaster's own chance of this, stated with the estimate: 85%); the middle value lies on the limit itself.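

No step can be read between compound 1, compound 2, compound 3 and compound 4, since each is reported only as a limit: the limit of > 100000 nM in this assay, at which 4 of the 4 values shown sit.

The compounds shown leave open whether these four differ at all, and whether any change on the shared core would give a measured number.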